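The source may report more compounds than this note shows. Statements on the series, on what has been measured and on what is new or still open speak of the compounds shown alone.

Measured compounds:
compound 1, `O=C(Nc1ccc(Cl)c(-c2nnc3c(Cl)cccn23)c1)c1ccc(Cl)cc1`, 58400 nM
compound 2, `O=C(Nc1ccc(Cl)c(-c2nnc3c(Cl)cccn23)c1)c1ccc(Cl)cc1Cl`, 78200 nM

In a functional assay on MCF7 cells (Homo sapiens) for antiproliferative activity, read by MTT assay, with a stated time of 72 h (on this read-out lower numbers stand for stronger inhibition and higher numbers for weaker inhibition), compound 2 gives the highest of the two numbers, with compound 1 nearest, and a 1.3-fold higher number from compound 1 to compound 2 (0.13 log units; within the scatter) shows that gap lies within the scatter. Compound 3, `O=C(Nc1ccc(Cl)c(-c2nnc3c(Cl)cccn23)c1)c1ccccc1Cl`, differs from compound 2 by hydrogen in place of chloro on an aromatic carbon. Among the compounds with values here, the only step measured on this ring, a 1.3-fold higher number from compound 1 to compound 2 (0.13 log units; within the scatter), did nothing beyond the scatter, so removing a chloro from the same ring is expected to matter little in this assay. Compound 3 is therefore expected to give 65000 nM, between 25000 nM and 170000 nM, a step of a 1.2-fold lower number from compound 2 to compound 3 (0.08 log units; within the scatter).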

Compound 3, half-maximal inhibitory concentration: 92200 nM
The estimate for compound 3 lay 1.4-fold (0.15 log units) below the measured number; low and high end bracket the measured number.
By their numbers in this assay, from the lowest: compounds 1, 2 and 3 (each within the scatter of the next).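

In this assay, the 2,4-dichlorophenyl ring can lose its chloro to leave 2-chlorophenyl without leaving the scatter (a 1.2-fold higher number from compound 2 to compound 3 (0.07 log units; within the scatter)). Moving the single chloro, with 2-chlorophenyl in place of 4-chlorophenyl, also stays within the scatter (a 1.6-fold higher number from compound 1 to compound 3 (0.20 log units; within the scatter)), so on this ring neither the number of chloro groups nor their place has yet separated these compounds. No measurement offered here gives a reason for these numbers.

The compounds shown carry only chloro or hydrogen on this ring. On these data alone, whether an amine, a methoxy group or a carboxylic acid there would shift the number beyond the scatter remains open.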